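Replacing pyridin-4-yl with 4-methylphenyl in compound 1

The source may report more compounds than this note shows. Statements on the series, on what has been measured and on what is new or still open speak of the compounds shown alone.

In a functional assay on MCF-10A cells (Homo sapiens) for antiproliferative activity, with a stated time of 48 h (on this read-out higher numbers stand for an effect only at larger amounts of compound and lower numbers for an effect already at smaller amounts), compound 1 `COc1ccc2nc(C)cc(NCc3ccncc3)c2c1` gives 41600 nM, compound 2 `COc1ccc2nc(C)cc(SCc3ccc(F)cc3)c2c1` gives 50500 nM and compound 3 `COc1ccc2nc(C)cc(SCc3ccccc3)c2c1` gives 37100 nM. Compound 1 thus stands within the scatter of both other compounds. The change to compound 4 `COc1ccc2nc(C)cc(NCc3ccc(C)cc3)c2c1` is 4-methylphenyl in place of pyridin-4-yl on a saturated chain carbon bound to a nitrogen on an aromatic ring. Among the measured compounds shown here, no measured step covers this exchange directly. The nearest evidence is the swap of hydrogen for fluoro on an aromatic carbon, a 1.4-fold lower number from compound 2 to compound 3 (0.13 log units; within the scatter), which stays within the scatter, although its side chain differs from that of compound 1. No shift beyond the scatter is therefore expected in this assay. The expected step is a 1.2-fold lower number from compound 1 to compound 4 (0.08 log units; within the scatter). Compound 4 is estimated at 35000 nM, with an expected range of 16000 nM to 70000 nM.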

Compound 4, half-maximal effective concentration: 22400 nM
Estimate against measurement, compound 4: 1.6-fold (0.19 log units) above, within the range that was stated.
By their numbers in this assay, from the lowest: compounds 4, 3, 1 and 2 (each within the scatter of the next, the first and the last beyond it).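

At the place on a saturated chain carbon bound to a nitrogen on an aromatic ring, this assay now has its first direct step: a 1.9-fold lower number from compound 1 to compound 4 (0.27 log units; within the scatter). The exchange of pyridin-4-yl for 4-methylphenyl removes the ring nitrogen and adds a methyl at once, and the number stays within the scatter, so neither change is resolved alone. No measurement on hand accounts for the step.

Open, going by these compounds, is whether an amine or a carboxylic acid on this ring moves the number beyond the scatter. Also open, on these data alone, is what a longer chain does at this place.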